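The source may hold more compounds than are shown below. What is called first, only, known or untested is meant among the compounds shown, and "the series" means these compounds.

Working notes on the series

Compound 1 `O=C(Nc1cccc(-c2ccco2)c1)C1CCCN(C(=O)c2cc(C(F)(F)F)cc(C(F)(F)F)c2)C1` in an ADME assay on PC-3 cells (Homo sapiens) for cytotoxicity, read by WST assay, tested at 100 uM (a higher number here means more inhibition at the concentration tested (going by the name of the read-out), a lower number less inhibition), gives 0%. Compound 3 `N#Cc1cccc(C(=O)N2CCCC(C(=O)Nc3ccc(Cl)cc3)C2)c1` in this assay gives 0%, and compound 2 `O=C(Nc1cccc(OCCc2ccccn2)c1)C1CCCN(C(=O)c2cc(C(F)(F)F)cc(C(F)(F)F)c2)C1` gives 5%. The single-point step along the series, a number 5 percentage points higher from compound 1 to compound 2 (within the scatter), stays inside the usual scatter of repeated measurements. Compound 1 therefore stands level with compound 3 at the digits shown, the two together at the bottom of the three numbers; its nearest neighbour is compound 3 with no change at the digits shown, its furthest compound 2, and even that gap lies within the scatter.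

Compound 4 `O=C(Nc1ccc(Cl)cc1)C1CCCN(C(=O)c2cc(C(F)(F)F)cc(C(F)(F)F)c2)C1` is not yet measured. The change from compound 1 reads (4-chlorophenyl in place of 3-(furan-2-yl)phenyl on an amide-type nitrogen). Among the compounds with values here, the only measured step, from compound 1 to compound 2, alters the same aryl amide end of the shared core and moved the read-out by an amount within the scatter. Compound 3, which carries a 4-chlorophenyl on the same amide nitrogen but a different acyl group, gives a value at the floor of the read-out, as does compound 1. Nothing here points to a rise in this assay, so the expected step of a number 2 percentage points higher from compound 1 to compound 4 (within the scatter) is none beyond the scatter. Compound 4 is expected to give 2%, with a range from 0% to 12%.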

Compound 4, a percentage reported as inhibition, at one concentration (the size of the read-out at that concentration, not a potency): 14%
For compound 4 the middle estimate is 12 percentage points below the measured one; the whole stated range lies below it.
By their numbers in this assay, from the lowest: compounds 1, 3, 2 and 4 (each within the scatter of the next, the first and the last beyond it).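

Within the data shown here, on the amide-type nitrogen, the change to 4-chlorophenyl in place of 3-(furan-2-yl)phenyl gives the first step that clears the scatter in this assay (a number 14 percentage points higher from compound 1 to compound 4 (beyond the scatter)), whereas the earlier change at this same position stayed inside it (a number 5 percentage points higher from compound 1 to compound 2 (within the scatter)). The aryl group on this nitrogen can therefore shift the reading, but 4-chlorophenyl does not fix it alone: with that group in both and only the acyl end differing, compound 3 prints (0%) and compound 4 prints (14%). No measurement at hand accounts for the step, so its cause remains unassigned.

The compounds shown leave open whether the step belongs to the chlorine itself, to its place on the ring, or simply to the loss of the furan-2-yl ring. A plain phenyl, a 4-fluorophenyl or a phenyl carrying a carboxylic acid on the same nitrogen would be needed to separate these readings, and whether any such group moves the number further in this cell assay remains an open question.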